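Next sulfonyl substituent in the series: compound 3

A few compounds are considered here, and "the series" means these few. Any claim that something is new, unique, unknown or untested is made for them only; others in the source may bear on it.

Going by the values given here, in an ADME assay on MDCK cells (Canis lupus familiaris) for permeability, read by LC-MS, in the apical to basolateral direction, tested at 10 uM (a lower number here means that the compound crosses the layer more slowly, a higher number that the compound crosses the layer faster), compound 2 (`CC(C)n1cc(S(=O)(=O)c2ccc(CNC(=O)N3Cc4ccncc4C3)cc2)cn1`) gives 4.1 10^-6 cm/s and holds the lower of the two numbers so far. Compound 1 (`O=C(NCc1ccc(S(=O)(=O)c2ccccc2)cc1)N1Cc2ccncc2C1`) stands higher with 8.3 10^-6 cm/s on the same shared core.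

Compound 3 (`O=C(NCc1ccc(S(=O)(=O)C2CCN(C3COC3)CC2)cc1)N1Cc2ccncc2C1`) carries 1-(oxetan-3-yl)piperidin-4-yl in place of 1-isopropyl-1H-pyrazol-4-yl on a sulfonyl sulfur. The incoming group has no aromatic ring, whereas both groups measured at this place do, so the precedent is thin.

Among the compounds with values here, the only measured step on a sulfonyl sulfur is a 2.0-fold lower number from compound 1 to compound 2 (0.31 log units; beyond the scatter) with 1-isopropyl-1H-pyrazol-4-yl in place of phenyl. It is modest and beyond the scatter. On that single step, a further modest step toward a lower number is expected in this assay with low confidence, and a result within the scatter of compound 2 would not be surprising.

The expected move is a 1.4-fold lower number from compound 2 to compound 3 (0.14 log units; within the scatter) as estimated here. Compound 3 is estimated at 3 10^-6 cm/s (expected range from 1.2 10^-6 cm/s to 7 10^-6 cm/s).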

Compound 3, apparent permeability: 0.1 10^-6 cm/s
Compound 3: middle estimate off by 30-fold (1.48 log units), on the high side; measured number outside the range, below it.
By their numbers in this assay, from the lowest: compound 3; then compound 2; then compound 1.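

In this assay, going by these compounds alone, the place on the sulfonyl sulfur proves far more sensitive than the only earlier step, a 2.0-fold lower number from compound 1 to compound 2 (0.31 log units; beyond the scatter), could show: 1-(oxetan-3-yl)piperidin-4-yl gives a 41-fold lower number from compound 2 to compound 3 (1.61 log units; beyond the scatter) and, measured against phenyl, an 83-fold lower number from compound 1 to compound 3 (1.92 log units; beyond the scatter), both large and beyond the scatter. The counts under this change do not separate the groups, as 1-isopropyl-1H-pyrazol-4-yl and 1-(oxetan-3-yl)piperidin-4-yl have the same hydrogen-bond donor and acceptor counts and no net charge, and the clear structural difference is the exchange of a five-membered aromatic ring for a four-membered and a six-membered non-aromatic ring. No supporting measurement is available to account for the size of this step.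

The compounds shown leave open whether the large step goes with the piperidine ring, with the oxetane ring or with the absence of any aromatic ring on the sulfonyl sulfur, as these three features enter together in compound 3. A cyclohexyl group or a tetrahydropyran-4-yl group at this place would help to pull these features apart.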